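Swapping an acetyl group for hydrogen on compound 2

This account rests on a few compounds, and the source may have more. Where it says the series, first, only, none or still open, it means among the compounds named here.

Compound 1 `CC(=O)Oc1c(O)cc2oc(-c3ccccc3)cc(=O)c2c1O` gives 10500 nM
Compound 2 `CC(=O)Oc1cc2oc(-c3ccccc3)cc(=O)c2c(O)c1OCc1ccccc1` gives 16300 nM

Both values come from a functional assay on KB cells (Homo sapiens) for inhibition, with a stated time of 72 h (on this read-out higher numbers stand for weaker inhibition and lower numbers for stronger inhibition), and lie within the usual scatter of each other. Compound 2 stands at 16300 nM on this scale, level with compound 1 at 10500 nM once that scatter is allowed for. These two compounds differ in more than one place, so no single structural change has yet been measured on its own.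

Compound 3 `O=c1cc(-c2ccccc2)oc2cc(O)c(OCc3ccccc3)c(O)c12` is compound 2 with hydrogen in place of acetyl on an oxygen on an aromatic ring, which turns acetoxy to hydroxy. The counted difference reads hydrogen in place of acetyl on an oxygen on an aromatic ring and nothing else in the structure changes.

Compound 1 at 10500 nM and compound 2 at 16300 nM sit close together despite their differences, so no shift beyond the scatter is expected in this assay and no firm direction can be given. The expected change is a 1.4-fold lower number from compound 2 to compound 3 (0.13 log units; within the scatter) and this estimate stays inside the scatter. For compound 3 the estimated value is 12000 nM and a measurement is expected to fall between 5000 nM and 30000 nM in most repeats.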

Compound 3, half-maximal inhibitory concentration: 4300 nM
Compound 3: the middle estimate sits 2.8-fold (0.45 log units) above what was measured, and the stated range ends above it.
By their numbers in this assay, from the lowest: compound 3; then compounds 1 and 2 (each within the scatter of the next).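

Turning acetoxy to hydroxy, with hydrogen in place of acetyl on an oxygen on an aromatic ring, is the first single change with a measured effect in this assay, and it gives a 3.8-fold lower number from compound 2 to compound 3 (0.58 log units; beyond the scatter). The acetyl on compound 2 is therefore not needed for inhibition of these cells, and losing it leaves a compound that inhibits more strongly, which the earlier pair, level within the scatter and differing in more than one place, could not show. Benzyl in place of acetyl on an oxygen on an aromatic ring gives a 2.4-fold lower number from compound 1 to compound 3 (0.39 log units; beyond the scatter), so compound 3 stands as the strongest of the three, and in both steps an acetyl leaves and the number falls.

Still open, from the compounds shown here alone, is whether a smaller or larger group on this oxygen, such as a methyl ether, a longer chain or a chain ending in an amine or a carboxylic acid, would keep this gain or take it further. Why removing the acetyl lowers the number also stays unexplained, as nothing measured here addresses the cause.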